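Swapping Iodo for Ethyl at the Assay Limit

The source may report more compounds than this note shows. Statements on the series, on what has been measured and on what is new or still open speak of the compounds shown alone.

Of the compounds shown here, two sharing one core have been measured in a functional assay on MCF7 cells (Homo sapiens) for antiproliferative activity, read by WST assay, with a stated time of 3 days; on this read-out lower numbers stand for stronger inhibition and higher numbers for weaker inhibition. Compound 1 `CNc1cc(=O)[nH]c(=O)n1[C@@H]1O[C@H](CO)[C@@H](O)[C@H]1O` gives > 50000 nM, which is a limit of the assay and not a number. Compound 2 `O=c1[nH]c(=O)n([C@@H]2O[C@H](CO)[C@@H](O)[C@H]2O)c(I)c1F` gives > 50000 nM, which is also a limit. Compound 2 therefore has no numerical potency and stands at the limit of > 50000 nM in this assay, at which 2 of the 2 values shown sit.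

Compound 3 `CCc1c(F)c(=O)[nH]c(=O)n1[C@@H]1O[C@H](CO)[C@@H](O)[C@H]1O` has the core of compound 2 but carries ethyl in place of iodo on an aromatic carbon. The change lies next to the ring nitrogen and ortho to a fluoro group. For the measured compounds named here, no measured step between related compounds shows how far such a change can move the read-out in this assay. The expectation therefore rests on compound 2, whose result of > 50000 nM is a limit. No change beyond the scatter is expected, and neither direction is favoured, so the estimated step of a number no higher from compound 2 to compound 3 (the limit leaves the size open) is small. The assay will most likely report only a limit again. Should it return a number, the expected value for compound 3 is 50000 nM, within an estimated range from 20000 nM to 100000 nM.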

Compound 3, half-maximal inhibitory concentration: 31400 nM
Compound 3: middle estimate off by 1.6-fold (0.20 log units), on the high side; measured number inside the range.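

In this assay, compound 3 returns a number, 31400 nM. The other compounds shown give only limits, so this is the first evidence that the shared core can produce a measurable read-out. Ethyl in place of iodo on an aromatic carbon gives an at least 1.5-fold lower number from compound 2 to compound 3 (0.20 log units; that floor lies within the scatter), which shows that a change at this place, next to the ring nitrogen and ortho to a fluoro group, can bring the read-out into the measurable range, though the floor of the step does not by itself establish a real gain. From the compounds shown here alone, the true size of the step stays unknown because its starting point is a limit and not a number: the limit of > 50000 nM in this assay, at which 2 of the 3 values shown sit.

The compounds shown leave open whether a longer chain such as propyl, or an amine or a carboxylic acid, would move the read-out further at this same place, and so whether ethyl is a special case or part of a trend. They also leave open how much the value of compound 3 depends on the fluoro group, since no compound shown carries chloro or hydrogen there alongside the ethyl.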